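Halogen pattern on the benzyl group of the spiro series

The source may report more compounds than this note shows. Statements on the series, on what has been measured and on what is new or still open speak of the compounds shown alone.

Three analogues sharing one core have been measured in an assay on FRT cells for positive allosteric modulation of Cystic fibrosis transmembrane conductance regulator variant N1303K (Homo sapiens), in the presence of a further agent that is not named here; a higher number here means that more compound is needed for the effect, a lower number that less compound is needed. Compound 1 `COc1ccc2[nH]c3c(c2c1)CCNC31CCN(Cc2ccccc2)CC1`, carrying an unsubstituted benzyl group, gives 12600 nM. Compound 2 `COc1ccc2[nH]c3c(c2c1)CCNC31CCN(Cc2ccc(Cl)cc2Cl)CC1` gives 1800 nM, and compound 3 `COc1ccc2[nH]c3c(c2c1)CCNC31CCN(Cc2c(F)ccc(Cl)c2F)CC1` gives 1500 nM, the lowest number of the three; compound 3 stands within the scatter of compound 2 and well apart from compound 1, with an 8.4-fold lower number from compound 1 to compound 3 (0.92 log units; beyond the scatter) and a 1.2-fold lower number from compound 2 to compound 3 (0.08 log units; within the scatter). The move from unsubstituted to halogenated benzyl was also seen as a 7.0-fold lower number from compound 1 to compound 2 (0.85 log units; beyond the scatter).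

Compound 4 `COc1ccc2[nH]c3c(c2c1)CCNC31CCN(Cc2ccccc2Cl)CC1` is not yet measured. Its change from compound 3 is 2-chlorophenyl in place of 3-chloro-2,6-difluorophenyl on a saturated chain carbon bound to an amine nitrogen in a ring, so one chlorine remains and the two fluorines are lost. The relevant steps are those from compound 1 to compound 2 and compound 3, where adding halogens lowered the number by a modest amount; removing two of three halogens is expected to give back part of that gain. For compound 4 the expected step is a 2.3-fold higher number from compound 3 to compound 4 (0.37 log units; beyond the scatter), toward a higher number. Compound 4 is estimated at 3500 nM, within 1300 nM to 9000 nM.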

Compound 4, half-maximal effective concentration: 2200 nM
Compound 4: the middle estimate sits 1.6-fold (0.20 log units) above what was measured, within the range that was stated.
By their numbers in this assay, from the lowest: compounds 3, 2 and 4 (each within the scatter of the next); then compound 1.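

A single chlorine on the benzyl group is enough for the step away from the unsubstituted compound, as 2-chlorophenyl in place of phenyl gives a modest change beyond the scatter (a 5.7-fold lower number from compound 1 to compound 4 (0.76 log units; beyond the scatter)). Further halogens add nothing that can be read in this assay: the extra chlorine of compound 2 (a 1.2-fold higher number from compound 2 to compound 4 (0.09 log units; within the scatter)) and the change from 3-chloro-2,6-difluorophenyl (a 1.5-fold higher number from compound 3 to compound 4 (0.17 log units; within the scatter)) both stay within the scatter, so compounds 2, 3 and 4 cannot be ordered. No evidence in hand bears on what lies behind this flat response.

On these data alone, whether the step depends on a halogen at all stays open, since a methyl, methoxy or nitrile group in place of the chlorine of compound 4 would test it. As far as these compounds go, the effect of a longer chain between the amine nitrogen and the aromatic ring also remains unknown.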